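Adding a fluorine to the N-aryl ring of compound 2

The compounds below may be only part of what the source reports. "The series", "measured", "known", "first", "only" and "open" are said of these compounds alone.

Two compounds of this series have numbers in a functional assay on A549 cells (Homo sapiens) for antiproliferative activity, read by MTT assay, with a stated time of 72 h; a lower number here means a stronger inhibitor, a higher number a weaker inhibitor. Compound 1 `O=C(Nc1ccc(Oc2ccnc3[nH]ccc23)cc1)c1cc2cccnc2n(-c2ccc(Cl)cc2)c1=O` gives 290 nM in this assay. Within the data shown here, compound 2 `O=C(Nc1ccc(Oc2ccnc3[nH]ccc23)c(F)c1)c1cc2cccnc2n(-c2ccc(Cl)cc2)c1=O` gives 110 nM in this assay, the lowest of the two numbers; the only measured step, a 2.6-fold lower number from compound 1 to compound 2 (0.42 log units; beyond the scatter), is a modest one. Compound 3 `O=C(Nc1ccc(Oc2ccnc3[nH]ccc23)c(F)c1)c1cc2cccnc2n(-c2ccc(F)c(Cl)c2)c1=O` is not yet measured. It differs from compound 2 by 3-chloro-4-fluorophenyl in place of 4-chlorophenyl on an aromatic nitrogen. Among the measured compounds shown here, no measured step bears on this change: the single step available concerns a fluoro in place of hydrogen on a different ring, and nothing in the data speaks to a change on the ring attached to the aromatic nitrogen. The expected step is therefore none beyond the scatter, a 1.1-fold lower number from compound 2 to compound 3 (0.04 log units; within the scatter). For compound 3 in this assay the estimate is 100 nM, with a range from 40 nM to 260 nM.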

Compound 3, half-maximal inhibitory concentration: 630 nM
Beside the measured number, compound 3's estimate is 6.3-fold (0.80 log units) below it, and the stated range ends below it.
By their numbers in this assay, from the lowest: compound 2; then compound 1; then compound 3.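

At this position, the ring on the aromatic nitrogen proves sensitive in this assay: replacing 4-chlorophenyl with 3-chloro-4-fluorophenyl gives a 5.7-fold higher number from compound 2 to compound 3 (0.76 log units; beyond the scatter). Among these compounds, the earlier step concerned a fluoro on a different ring, so this is the first measured sign that a change on this ring can carry a cost, and here it undoes the lower number seen with compound 2. Nothing measured here accounts for the step.

The change alters two things at once, since the chlorine moves and a fluorine enters, and the compounds shown do not separate these two contributions. Nor do they show how this position would respond to a plain phenyl, a pyridyl group or a methoxyphenyl group on the aromatic nitrogen.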